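One Nitro Group, Two Cores, One Expected Step

The source may hold more compounds than are shown below. What is called first, only, known or untested is meant among the compounds shown, and "the series" means these compounds.

Values in a functional assay on HCT-116 cells (Homo sapiens) for cytotoxicity, read by MTT assay (on this read-out higher numbers stand for weaker inhibition and lower numbers for stronger inhibition), for the three measured compounds:
compound 1, `O=[N+]([O-])c1ccc2[nH]c(CNc3c([N+](=O)[O-])ccc4ncccc34)nc2c1`, gives 256000 nM
compound 2, `CC1=NN(Cc2nc3ccccc3[nH]2)C(=O)C1`, gives 42000 nM
compound 3, `O=[N+]([O-])c1ccc2ncccc2c1NCc1nc2ccccc2[nH]1`, gives 204000 nM

Compound 2 has the lowest number of the three, and its distance to compound 3 and to compound 1 is in both cases beyond the scatter, so on this read-out it is the strongest of the three. Compound 3 and compound 1 share one core and differ in a single place: nitro in place of hydrogen on an aromatic carbon. That change gave a 1.3-fold higher number from compound 3 to compound 1 (0.10 log units; within the scatter), so adding the nitro group left the read-out essentially unchanged on that core. How the core of compound 2 differs from the core of compound 3 is not broken down here.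

Compound 4, `CC1=NN(Cc2nc3cc([N+](=O)[O-])ccc3[nH]2)C(=O)C1`, has not yet been measured. It stands to compound 2 as compound 1 stands to compound 3: nitro in place of hydrogen on an aromatic carbon. The two descriptions of the place agree word for word, so this is the same change, now made on a different core. Among the measured compounds shown here, with only one earlier example to rest on, the expectation is that the step will again be small: from compound 2 to compound 4, a 1.2-fold higher number from compound 2 to compound 4 (0.08 log units; within the scatter) is expected in this assay, because the same change gave a 1.3-fold higher number from compound 3 to compound 1 (0.10 log units; within the scatter). Compound 4 is therefore estimated at 50000 nM, with a likely range from 20000 nM to 130000 nM.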

Compound 4, half-maximal inhibitory concentration: 200000 nM
For compound 4 the middle estimate is 4.0-fold (0.60 log units) below the measured one, and the stated range ends below it.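

Putting nitro in place of hydrogen on an aromatic carbon gave a 4.8-fold higher number from compound 2 to compound 4 (0.68 log units; beyond the scatter) in this assay, so on the core of compound 2 this single change clearly weakened the read-out. Set beside the earlier step, the size of the effect did not carry over from one core to the other: the same change on two cores in this assay, a 1.3-fold higher number (0.10 log units; within the scatter) from compound 3 to compound 1 and a 4.8-fold higher number (0.68 log units; beyond the scatter) from compound 2 to compound 4, 3.8-fold (0.58 log units) apart, beyond the scatter of two such steps With only these two pairs, the result shows that the step measured on one core was a poor guide to the step on the other, but it does not show which feature of the cores makes the difference or how the same change would behave on a third core.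

In the compounds shown, this place holds only hydrogen or nitro, so it remains open whether another group there, such as an amine, a carboxylic acid or a chlorine atom, would also separate the two cores in this way. As far as these compounds go, it also remains open whether nitro on a different aromatic carbon would give a similar step on the core of compound 2, and whether the difference between the two cores would hold in other cell lines.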